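This account rests on a few compounds, and the source may have more. Where it says the series, first, only, none or still open, it means among the compounds named here.

Of the compounds shown here, three sharing one core have been measured in a functional assay on 1321-N1 cells for agonist activity at P2Y purinoceptor 4 (Homo sapiens), read by scintillation counting and inositol phosphate accumulation; a higher number here means that more compound is needed for the effect, a lower number that less compound is needed. Compound 1 `O=c1[nH]/c(=N\OCCOc2ccccc2)ccn1[C@@H]1O[C@H](COP(=O)(O)OP(=O)(O)OP(=O)(O)O)[C@@H](O)[C@H]1O` gives 430 nM. Compound 2 `O=c1[nH]/c(=N\OCCCc2cccc(F)c2)ccn1[C@@H]1O[C@H](COP(=O)(O)OP(=O)(O)OP(=O)(O)O)[C@@H](O)[C@H]1O` gives 100 nM, and compound 3 `O=c1[nH]/c(=N\OCCCc2ccc(Br)cc2)ccn1[C@@H]1O[C@H](COP(=O)(O)OP(=O)(O)OP(=O)(O)O)[C@@H](O)[C@H]1O` gives 141 nM. Compound 3 thus stands second highest of the three numbers: its gap to compound 2 is within the scatter, while a 3.0-fold lower number from compound 1 to compound 3 (0.48 log units; beyond the scatter). Compound 4 `O=c1[nH]/c(=N\OCCCc2cccc(I)c2)ccn1[C@@H]1O[C@H](COP(=O)(O)OP(=O)(O)OP(=O)(O)O)[C@@H](O)[C@H]1O` differs from compound 3 in one place: 3-iodophenyl in place of 4-bromophenyl on a saturated chain carbon, three bonds along the chain from an oxygen. Among the compounds with values here, the one step that bears on this swaps one halogenated phenyl for another, where a 1.4-fold higher number from compound 2 to compound 3 (0.15 log units; within the scatter). The remaining step, a 4.3-fold lower number from compound 1 to compound 2 (0.63 log units; beyond the scatter), replaces phenoxy with a benzyl group and does not bear on it. A change of a 1.2-fold lower number from compound 3 to compound 4 (0.07 log units; within the scatter) is therefore expected, not beyond the scatter. Compound 4 is estimated at 120 nM, with a range from 50 nM to 300 nM.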

Compound 4, half-maximal effective concentration: 114 nM
Beside the measured number, compound 4's estimate is 1.1-fold (0.02 log units) above it; the range from low to high includes it.
By their numbers in this assay, from the lowest: compounds 2, 4 and 3 (each within the scatter of the next); then compound 1.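

In this assay, the change to 3-iodophenyl leaves the number within the scatter against both other halogenated compounds (a 1.2-fold lower number from compound 3 to compound 4 (0.09 log units; within the scatter)) and (a 1.1-fold higher number from compound 2 to compound 4 (0.06 log units; within the scatter)), so these three halogenated phenyl groups on the chain cannot be told apart. The drop from the phenoxy compound also holds with iodine as the halogen (a 3.8-fold lower number from compound 1 to compound 4 (0.58 log units; beyond the scatter)), and no compound shown goes against it. No measurement shown explains these numbers. From the compounds shown here alone, whether the phenyl ring needs a halogen at all stays open. So does whether an amine or a carboxylic acid on that ring, or a longer chain, would keep the number at this level.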